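A few compounds are considered here, and "the series" means these few. Any claim that something is new, unique, unknown or untested is made for them only; others in the source may bear on it.

In a functional assay on CHO-K1 cells for antagonist activity at Orexin/Hypocretin receptor type 1 (Homo sapiens), read by FLIPR and calcium flux (on this read-out higher numbers stand for weaker inhibition and lower numbers for stronger inhibition), the three measured compounds stand as follows:

compound 1 `C#Cc1ccnc(O[C@@H]2CC[C@@H](C)N(C(=O)c3ccccc3-n3nccn3)C2)c1`: 240 nM
compound 2 `CC(C)OC(=O)c1ccccc1C(=O)N1C[C@H](Oc2cc(C#N)ccn2)CC[C@H]1C`: 3300 nM
compound 3 `COC(=O)c1ccnc(O[C@@H]2CC[C@@H](C)N(C(=O)c3ccccc3-n3nccn3)C2)c1`: 1800 nM

Compound 2 gives the highest number of the three. The value of compound 3 lies within the usual scatter of that of compound 2, so the two cannot be told apart on these numbers, whereas compound 1 sits beyond the scatter with a clearly lower number.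

Compound 4 `CCOC(=O)c1ccccc1C(=O)N1C[C@H](Oc2cc(C#N)ccn2)CC[C@H]1C` is the unmeasured analogue of compound 2. It differs from compound 2 in one place: hydrogen in place of methyl on a saturated chain carbon bound to an oxygen next to a carbonyl group and a saturated chain carbon. Cut one bond further out, this reads isopropoxycarbonyl to ethoxycarbonyl.

Within the data shown here, the single measured step, a 7.5-fold higher number from compound 1 to compound 3 (0.88 log units; beyond the scatter), concerns a group on an aromatic carbon in a different part of the shared core and says nothing about the ester chain. Among the measured compounds shown here, no step among the measured compounds bears on the change from compound 2 to compound 4. With nothing to point either way, the expected step of a 1.1-fold lower number from compound 2 to compound 4 (0.04 log units; within the scatter) in this assay is none beyond the scatter. Compound 4 is therefore estimated at 3000 nM, with a range from 1200 nM to 7500 nM.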

Compound 4, half-maximal inhibitory concentration in the Orexin/Hypocretin receptor type 1 assay: 7100 nM
Estimate against measurement, compound 4: 2.4-fold (0.37 log units) below, within the range that was stated.
By their numbers in the Orexin/Hypocretin receptor type 1 assay, from the lowest: compound 1; then compounds 3 and 2 (each within the scatter of the next); then compound 4.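

In the Orexin/Hypocretin receptor type 1 assay, the first step measured at this ester chain shows that the change is not neutral: isopropoxycarbonyl to ethoxycarbonyl gives a 2.2-fold higher number from compound 2 to compound 4 (0.33 log units; beyond the scatter), so losing this one methyl weakens inhibition modestly. In a physicochemical assay for solubility, at pH 7 (a lower number here means a less soluble compound, a higher number a more soluble compound), compound 2 gives 115000 nM and compound 4 gives 121000 nM, and with a 1.1-fold higher number from compound 2 to compound 4 (0.02 log units; within the scatter) the same change leaves no distinction on that read-out. No measurement available here offers a reason for the step in the Orexin/Hypocretin receptor type 1 assay.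

With only isopropoxycarbonyl and ethoxycarbonyl shown on this chain, it remains open how a methyl ester, a longer chain such as butyl, or a carboxylic acid would read in the Orexin/Hypocretin receptor type 1 assay. As far as these compounds go, it is also open whether the same change would give a similar step on another core.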